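The source may report more compounds than this note shows. Statements on the series, on what has been measured and on what is new or still open speak of the compounds shown alone.

Measured in a functional assay on MCF7 cells (Homo sapiens) for antiproliferative activity, read by MTT assay, with a stated time of 48 h; on this read-out lower numbers stand for stronger inhibition and higher numbers for weaker inhibition:
- Compound 1 `COc1ccc(C(=O)c2cc(OC)c(OC)c(OC)c2)c(NC(=O)CO)c1`: 230 nM
- Compound 2 `CNCC(=O)Nc1cc(OC)ccc1C(=O)c1cc(OC)c(OC)c(OC)c1`: 550 nM
- Compound 3 `COc1ccc(C(=O)c2cc(OC)c(OC)c(OC)c2)c(NC(=O)CN(C)C)c1`: 790 nM

Compound 3 has the largest number of the three, but it does not stand alone there. The set shows a 1.4-fold higher number from compound 2 to compound 3 (0.16 log units; within the scatter), so its value cannot be told apart from that of the compound carrying methylamino. The gap to the hydroxy compound is clearer, with a 3.4-fold higher number from compound 1 to compound 3 (0.54 log units; beyond the scatter).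

Compound 4 `COc1ccc(C(=O)c2cc(OC)c(OC)c(OC)c2)c(NC(=O)CN)c1` has not yet been measured. It carries amino in place of dimethylamino on a saturated chain carbon bound to a carbonyl carbon.

Two kinds of measured step bear on this change. The closest is the one that adds a single methyl on the amine nitrogen, a 1.4-fold higher number from compound 2 to compound 3 (0.16 log units; within the scatter), and compound 4 goes one methyl further back along that same line. The steps away from hydroxy are also relevant, a 2.4-fold higher number from compound 1 to compound 2 (0.38 log units; beyond the scatter) and a 3.4-fold higher number from compound 1 to compound 3 (0.54 log units; beyond the scatter), and they are modest. None of these steps is large, so only a small shift toward a lower number is expected in this assay, and it may not stand clear of the scatter.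

The expected step is a 1.8-fold lower number from compound 3 to compound 4 (0.24 log units; within the scatter). For compound 4 the estimated value is 450 nM, within an expected range from 170 nM to 1200 nM.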

Compound 4, half-maximal inhibitory concentration: 270 nM
For compound 4 the middle estimate is 1.7-fold (0.22 log units) above the measured one; the range from low to high includes it.
By their numbers in this assay, from the lowest: compounds 1 and 4 (each within the scatter of the next); then compounds 2 and 3 (each within the scatter of the next).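

In this assay, among these compounds, the earlier compounds left open whether any nitrogen group on this saturated chain carbon bound to a carbonyl carbon gives a higher number than hydroxy, but amino does not, with a 1.2-fold higher number from compound 1 to compound 4 (0.07 log units; within the scatter) leaving the two groups indistinguishable here. The clearer divide now lies with methyl on the amine nitrogen: taking off both methyls gives a 2.9-fold lower number from compound 3 to compound 4 (0.47 log units; beyond the scatter) and taking off the only methyl gives a 2.0-fold lower number from compound 2 to compound 4 (0.31 log units; beyond the scatter), whereas the earlier step that added the second methyl stayed within the scatter. Across these four compounds, the two without methyl on a nitrogen at this place, compound 1 and compound 4, have lower numbers than the two with it, compound 2 and compound 3, and no compound here goes against that split.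

As far as these compounds go, whether a longer chain carrying the amine, or a methoxy group or a carboxylic acid at this place, would fall with compound 1 and compound 4 or with compound 2 and compound 3 remains open. Nothing measured here gives a reason for the split.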